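Compound 1 to compound 4: removing the trifluoromethyl group

The source may report more compounds than this note shows. Statements on the series, on what has been measured and on what is new or still open speak of the compounds shown alone.

Values in an ADME assay on MDBK cells (Bos taurus) for cytotoxicity, read by MTT assay, with a stated time of 72 h; on this read-out higher numbers stand for lower toxicity in this test and lower numbers for higher toxicity in this test:
compound 1 `FC(F)(F)c1ccc(NCc2cn(-c3ccccc3)nc2-c2ccc(Br)cc2)cc1` gives 46000 nM
compound 2 `FC(F)(F)c1ccc(NCc2cn(-c3ccccc3)nc2-c2ccc(Cl)cc2)cc1` gives 31000 nM
compound 3 `Cc1ccc(-c2nn(-c3ccccc3)cc2CNc2ccc(C(F)(F)F)cc2)cc1` gives > 100000 nM as a limit of the assay

Going by the values given here, compound 1 (46000 nM) holds one of only two true numbers in the set, and the other lies close by (a 1.5-fold lower number from compound 1 to compound 2 (0.17 log units; within the scatter)). Compound 3 stands at a limit (> 100000 nM) and not at a number. The two steps reaching that limit (an at least 2.1-fold higher number from compound 1 to compound 3 (0.33 log units; beyond the scatter) and an at least 3.2-fold higher number from compound 2 to compound 3 (0.50 log units; beyond the scatter)) are at least modest, but they concern a different place from the one changed now.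

Compound 4 `Brc1ccc(-c2nn(-c3ccccc3)cc2CNc2ccccc2)cc1` differs from compound 1 by hydrogen in place of trifluoromethyl on an aromatic carbon. Among the compounds with values here, no measured step touches this place, so the data give no size for it. In this assay no step beyond the scatter is therefore expected, and no direction is favoured. The expected change is a 1.1-fold higher number from compound 1 to compound 4 (0.04 log units; within the scatter) on this estimate. For compound 4 the estimated value is 50000 nM with an expected range from 20000 nM to 100000 nM in this assay's terms.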

Compound 4, half-maximal cytotoxic concentration: > 100000 nM
Compound 4: only a limit was reported; the forecaster's own chance of this, stated with the estimate: 25%; middle value at least 2.0-fold (0.30 log units) from the limit.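

The change from 4-(trifluoromethyl)phenyl to phenyl gives the first step read at this position in this assay, and it lies beyond the scatter: an at least 2.1-fold higher number from compound 1 to compound 4 (0.33 log units; beyond the scatter). Compound 4 gives > 100000 nM, which is a limit of the assay. The trifluoromethyl group is therefore not required for the higher number, and with bromo held constant its removal goes with lower toxicity in this test, but the full size of the step stays unknown because the value is a limit: the limit of > 100000 nM in this assay, at which 2 of the 4 values shown sit.

As far as these compounds go, whether the same change holds with chloro or methyl in place of bromo remains open. Also open, from the compounds shown here alone, is what an amine, a carboxylic acid or a longer chain at this place would give on this read-out.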